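A few compounds are considered here, and "the series" means these few. Any claim that something is new, unique, unknown or untested is made for them only; others in the source may bear on it.

Three compounds have been tested in a functional assay on MDA-MB-231 cells (Homo sapiens) for inhibition, read by MTT assay, with a stated time of 48 h; a higher number here means a weaker inhibitor, a lower number a stronger inhibitor:

compound 1 `COc1ccc(-c2cc(/C=C/C(=O)c3ccc(N)cc3)[nH]n2)cc1`, 1700 nM;
compound 2 `COc1cc(-c2cc(/C=C/C(=O)c3ccc(Cl)c(Cl)c3)[nH]n2)cc(OC)c1OC`, 2100 nM;
compound 3 `COc1cc2c(cc1OC)C(=O)/C(=C/c1cc(-c3cc(OC)c(OC)c(OC)c3)n[nH]1)C2`, 2500 nM.

Compound 2 stands second highest of the three numbers. Its nearest neighbour is compound 3 and its furthest is compound 1, and both gaps fall within the usual scatter of this assay, so the three cannot really be told apart. Compound 4 `COc1ccc(C(=O)/C=C/c2cc(-c3cc(OC)c(OC)c(OC)c3)n[nH]2)cc1F` differs from compound 2 in one place: 3-fluoro-4-methoxyphenyl in place of 3,4-dichlorophenyl on a carbonyl carbon. For the measured compounds named here, no measured pair shows what this change does in this assay. The three measured compounds carry quite different groups yet give numbers that sit close together, so no step beyond the scatter is expected in either direction. Compound 4 is therefore estimated at 2000 nM, with a range from 800 nM to 5000 nM, and the expected step is a 1.1-fold lower number from compound 2 to compound 4 (0.02 log units; within the scatter).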

Compound 4, half-maximal inhibitory concentration: 2700 nM
Beside the measured number, compound 4's estimate is 1.4-fold (0.13 log units) below it, within the range that was stated.
By their numbers in this assay, from the lowest: compounds 1, 2, 3 and 4 (each within the scatter of the next).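

In this assay, putting 3-fluoro-4-methoxyphenyl in place of 3,4-dichlorophenyl on a carbonyl carbon gives a 1.3-fold higher number from compound 2 to compound 4 (0.11 log units; within the scatter). For the compounds shown here, this is the first one-place comparison in the set, and it shows that this position holds either aromatic ring without a difference that can be told from the scatter. No measurement is available that would explain this result. Still open, on these data alone, is whether a phenyl ring carrying a carboxylic acid, or a longer carbon chain with no ring at all, on that carbonyl carbon would shift the number beyond the scatter.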